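Methoxy for Trifluoromethyl on the Ketone Aryl Ring

The compounds below may be only part of what the source reports. "The series", "measured", "known", "first", "only" and "open" are said of these compounds alone.

Compound 1, `COC(=O)c1cc(-c2cccc(NC(=O)c3ccc(/C=C/C(=O)c4cccc(F)c4)cc3)c2)on1`: > 40 ug/mL
Compound 2, `CCCOc1ccc(C(=O)/C=C/c2ccc(C(=O)Nc3cccc(-c4cc(C(=O)OC)no4)c3)cc2)cc1`: > 40 ug/mL
Compound 3, `COC(=O)c1cc(-c2cccc(NC(=O)c3ccc(/C=C/C(=O)c4cccc(C(F)(F)F)c4)cc3)c2)on1`: > 20 ug/mL

Three compounds share one core and differ only in the aryl group on the carbonyl carbon. In an ADME assay on Vero cells (Chlorocebus sabaeus) for cytotoxicity, read by MTT assay, with a stated time of 72 h (a lower number here means that less compound is tolerated, a higher number that more compound is tolerated), compound 1 reaches only a limit of the assay, > 40 ug/mL. Compound 2 likewise gives only a limit in this assay, > 40 ug/mL. Compound 3 also gives a limit, > 20 ug/mL. For the measured compounds named here, every value so far is a limit and not a number: the limit of > 40 ug/mL in this assay, at which 2 of the 3 values shown sit, and (the limit of > 20 ug/mL in this assay, at which 1 of the 3 values shown sits). The three steps among them are accordingly unreadable: a step that the two limits leave unreadable from compound 1 to compound 2, a step that the two limits leave unreadable from compound 1 to compound 3 and a step that the two limits leave unreadable from compound 2 to compound 3. Compound 3 thus stands where nothing in this assay separates it from the other two; all three were tolerated up to the concentration tested.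

Compound 4, `COC(=O)c1cc(-c2cccc(NC(=O)c3ccc(/C=C/C(=O)c4cccc(OC)c4)cc3)c2)on1`, differs from compound 3 in one place: methoxy in place of trifluoromethyl on an aromatic carbon. Going by the values given here, none of the measured steps has a readable size, so none gives a direction for this change; they show only that exchanging the group on this aromatic carbon left each compound tolerated to its limit. Compound 4 is therefore expected to show no step beyond the scatter, a step that the limit leaves unreadable from compound 3 to compound 4. Compound 4 is estimated at 60 ug/mL, with a range from 20 ug/mL to 200 ug/mL, and most likely again reported only as a limit.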

Compound 4, half-maximal cytotoxic concentration: > 100 ug/mL
Compound 4 ended at the assay's limit; the forecaster's own chance of this, stated with the estimate: 75%; at least 1.6-fold (0.22 log units) between middle value and limit.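

In this assay compound 4 gives > 100 ug/mL, which is a limit of the assay and not a number. For the compounds shown here, the values of compounds 1, 2 and 3 are limits too, so no step joining compound 4 to them can be read. Left open is what concentration of any of the four compounds is not tolerated in this assay, and whether the aryl group on the carbonyl carbon changes it.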